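The compounds below may be only part of what the source reports. "The series", "measured", "known", "first", "only" and "open" are said of these compounds alone.

Measured compounds in a functional assay for antagonist activity at transient receptor potential cation channel subfamily V member 1 (Homo sapiens), read by FLIPR and calcium flux; a higher number here means a weaker inhibitor, a lower number a stronger inhibitor:
- compound 1 `O=C1COc2ccc(NC(=O)C3CCN(c4ccccc4Cl)CC3)cc2N1`: 220 nM
- compound 2 `O=C1COc2ccc(NC(=O)C3CCN(c4cccc(Br)c4)CC3)cc2N1`: 330 nM
- compound 3 `O=C(Nc1cnc2ccccc2c1)C1CCN(c2cccc(C(F)(F)F)c2)CC1`: 600 nM

Compound 1 gives the lowest of the three numbers. Its nearest neighbour is compound 2, with a 1.5-fold higher number from compound 1 to compound 2 (0.18 log units; within the scatter), a gap that lies within the scatter, so no order between compound 1 and compound 2 can be read from these two values. Within the data shown here, compound 3, which carries a different core, lies furthest from compound 1, and that gap is beyond the scatter; no single-point step connects the two, so only the two values themselves are known.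

Compound 4 `Cc1cccc(N2CCC(C(=O)Nc3ccc4c(c3)NC(=O)CO4)CC2)c1` is the next member awaiting a number in this assay. Relative to compound 1 the change is 3-methylphenyl in place of 2-chlorophenyl on an amine nitrogen in a ring.

Among the measured compounds shown here, the only measured step that bears on this change is the one from compound 1 to compound 2, which also exchanges the aryl group on the amine nitrogen in a ring and gave a 1.5-fold higher number from compound 1 to compound 2 (0.18 log units; within the scatter), within the scatter. On that single precedent the exchange of one aryl group for another at this place is expected to move the number little, and no direction beyond the scatter is expected for a 1.4-fold higher number from compound 1 to compound 4 (0.13 log units; within the scatter). Compound 4 is therefore estimated at 300 nM, with a range from 120 nM to 750 nM.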

Compound 4, half-maximal inhibitory concentration: 490 nM
Beside the measured number, compound 4's estimate is 1.6-fold (0.21 log units) below it; the measured number falls inside the stated range.
By their numbers in this assay, from the lowest: compounds 1, 2, 4 and 3 (each within the scatter of the next, the first and the last beyond it).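

In this assay, the exchange of aryl groups on the amine nitrogen in a ring now gives a step beyond the scatter: 3-methylphenyl in place of 2-chlorophenyl gives a 2.2-fold higher number from compound 1 to compound 4 (0.35 log units; beyond the scatter), a modest loss that shows this place is not indifferent to the aryl group it carries. The step of methyl in place of bromo on an aromatic carbon gives a 1.5-fold higher number from compound 2 to compound 4 (0.17 log units; within the scatter), so no order can be read between the 3-bromophenyl and 3-methylphenyl members of the series, and compound 2 and compound 4 both rest on a single measured pair each with compound 1. Among these compounds, nothing measured beyond these values bears on the result, and the data offer no account of the step.

The step from compound 1 to compound 4 changes both the substituent and where it sits on the aryl ring, so the compounds shown cannot separate the two changes; 2-methylphenyl and 3-chlorophenyl on the shared core would each isolate one of them. On these data alone, how an unsubstituted phenyl or a methoxyphenyl would compare at this place also stays open.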